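Acetyl for dimethylamino on the shared core

This account rests on a few compounds, and the source may have more. Where it says the series, first, only, none or still open, it means among the compounds named here.

Measured compounds:
compound 1 `COc1cc(C)cc(-c2c(-c3ccnc(-c4ccc(N(C)C)cc4)c3)cnn2CC#N)c1`: 1%
compound 2 `Cc1cc(O)cc(-c2nn(CC#N)cc2-c2ccnc(-c3ccc(Oc4ccccc4)cc3)c2)c1`: 13%
compound 3 `COc1cc(C)cc(-c2nn(CC#N)cc2-c2ccc(-c3cccc(C(C)=O)c3)nc2)c1`: -39%

In a functional assay on SF-539 cells (Homo sapiens) for cytotoxicity, read by sulforhodamine B assay, with a stated time of 48 h, tested at 1 uM (on this read-out lower numbers stand for a stronger effect and higher numbers for a weaker effect at the one concentration tested), compound 1 gives 1%, the second highest of the three numbers. Compound 2 sits higher by a gap beyond the scatter; compound 3 sits far lower, also beyond the scatter. Compound 4 `COc1cc(C)cc(-c2c(-c3ccnc(-c4ccc(C(C)=O)cc4)c3)cnn2CC#N)c1` is compound 1 with one change: acetyl in place of dimethylamino on an aromatic carbon. Going by the values given here, no pair of measured compounds carries this change alone. Compound 3, which also carries an acetyl on a six-membered aromatic ring of carbon only, gives -39%, the lowest number shown, yet its core and remaining groups differ from those of compound 1, so it is only a loose pointer. A downward step of moderate size is expected, a number 11 percentage points lower from compound 1 to compound 4 (beyond the scatter). Compound 4 is expected to give -10%, within -45% to 25%.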

Compound 4, a percentage reported as activity, at one concentration (the size of the read-out at that concentration, not a potency): -45%
Estimate against measurement, compound 4: 35 percentage points above; measured number inside the range.
By their numbers in this assay, from the lowest: compounds 4 and 3 (each within the scatter of the next); then compound 1; then compound 2.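

In this assay, going by these compounds alone, the change from 4-(dimethylamino)phenyl to 4-acetylphenyl gives a number 46 percentage points lower from compound 1 to compound 4 (beyond the scatter) and is the first single-change read at this position. The two groups have the same heavy-atom and hydrogen-bond acceptor counts, so these counts do not separate them, while the step shows that the position is sensitive to this exchange. Nothing available explains the size of the step.

Going by these compounds, it remains open whether a carboxylic acid or a primary amine in the same place would extend the step. On these data alone, it is also open whether this change would give a similar step on another core.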